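The compounds below may be only part of what the source reports. "The series", "measured", "known", "first", "only" and "open" are said of these compounds alone.

Compound 2, `Cc1cc(-c2ccccc2)n(/C(N)=N/S(=O)(=O)c2cc(C)c(Cl)cc2SCc2cccc3ccccc23)n1`, has the lowest of the two half-lives measured so far in an ADME assay on microsomes from liver (Homo sapiens) for metabolic stability, read by LC-MS, using NADPH, tested at 5 uM (on this read-out lower numbers stand for a shorter-lived compound and higher numbers for a longer-lived compound), namely 0.256 h. Within the data shown here, its only measured neighbour is compound 1, `Cc1cc(-c2ccccc2)n(/C(N)=N/S(=O)(=O)c2cc(C)c(Cl)cc2SCc2ccccc2C(F)(F)F)n1`, which in this assay gives 0.306 h; the step of a 1.2-fold lower number from compound 1 to compound 2 (0.08 log units; within the scatter), a swap of naphthalen-1-yl for 2-(trifluoromethyl)phenyl on a saturated chain carbon bound to a sulfur, stays within the scatter. Compound 3, `Cc1cc(-c2ccccc2)n(/C(N)=N/S(=O)(=O)c2cc(C)c(Cl)cc2SCc2ccccc2Cl)n1`, is the next member of the series and remains to be measured. The change from compound 2 is 2-chlorophenyl in place of naphthalen-1-yl on a saturated chain carbon bound to a sulfur. Among the measured compounds shown here, the one measured step at this position, the step from compound 1 to compound 2, was too small to show a direction, so a further swap of aryl group there is expected to move the half-life little, if at all, beyond the scatter. Compound 3 is therefore estimated to show a 1.2-fold higher number from compound 2 to compound 3 (0.07 log units; within the scatter), landing at about 0.3 h, with a range from 0.15 h to 0.6 h.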

Compound 3, half-life: 0.163 h
For compound 3 the middle estimate is 1.8-fold (0.26 log units) above the measured one; measured number inside the range.
By their numbers in this assay, from the lowest: compounds 3, 2 and 1 (each within the scatter of the next).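

In this assay the exchange of the two-ring naphthalen-1-yl for the one-ring 2-chlorophenyl gives a 1.6-fold lower number from compound 2 to compound 3 (0.20 log units; within the scatter) and the exchange of trifluoromethyl for chloro on an aromatic carbon gives a 1.9-fold lower number from compound 1 to compound 3 (0.27 log units; within the scatter) and so neither step lies beyond the scatter. Among these compounds, on a saturated chain carbon bound to a sulfur, three aryl groups can now be compared, and none of the steps among them shows a direction, which extends what the single earlier step could show. Nothing given here bears on what lies behind these half-lives.

The compounds shown leave open whether any group at this position would move the half-life beyond the scatter. An amine or a carboxylic acid in place of the aryl group would be one test of that, and its outcome cannot be read from these three compounds.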